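Series notes: removing the methoxy from compound 3

This account rests on a few compounds, and the source may have more. Where it says the series, first, only, none or still open, it means among the compounds named here.

For the measured compounds named here, the three measured members share one core and differ only in the aryl group carried on an oxygen on a saturated carbon. In an assay on HEK293 cells for positive allosteric modulation of metabotropic glutamate receptor 2 (Rattus norvegicus), read by thallium flux, with a stated time of 2.5 min (on this read-out higher numbers stand for larger maximal responses and lower numbers for smaller maximal responses), compound 1 `Cc1c(OCCCCOc2ccc(F)c(C(=O)O)c2)ccc(C(=O)CC2CCCC2)c1O` gives 81%. Compound 2 `Cc1c(OCCCCOCOc2ccc(C(=O)O)cc2)ccc(C(=O)CC2CCCC2)c1O` gives 95.4% in this assay, and compound 3 `COc1ccc(C(=O)O)cc1OCCCCOc1ccc(C(=O)CC2CCCC2)c(O)c1C` gives 91.8%. Compound 3 therefore stands second highest of the three; the gap a number 3.6 percentage points lower from compound 2 to compound 3 (within the scatter) is within the scatter, whereas a number 10.8 percentage points higher from compound 1 to compound 3 (beyond the scatter) lies beyond it, as does a number 14.4 percentage points higher from compound 1 to compound 2 (beyond the scatter).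

Compound 4 `Cc1c(OCCCCOc2cccc(C(=O)O)c2)ccc(C(=O)CC2CCCC2)c1O` is the next step from compound 3: hydrogen in place of methoxy on an aromatic carbon. Going by the values given here, no measured step removes the methoxy alone, so the expectation rests on how little the aryl pattern mattered between compound 2 and compound 3, where the whole group was exchanged and the maximal response moved only within the scatter. The two larger steps both start from compound 1, the member carrying the 3-carboxy-4-fluorophenyl group, which compound 4 does not have. A step in this assay of no more than the scatter is therefore expected, with no firm direction; the expected change is a number 1.8 percentage points lower from compound 3 to compound 4 (within the scatter). For compound 4 the estimated maximal response in this assay is 90%, within a range from 78% to 100%.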

Compound 4, largest response reached (reported as percent of maximum), in percent of the reference or control that the assay uses: 80.6%
Compound 4: the middle estimate sits 9.4 percentage points above what was measured; measured number inside the range.
By their numbers in this assay, from the lowest: compounds 4 and 1 (each within the scatter of the next); then compounds 3 and 2 (each within the scatter of the next).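

The methoxy is not a silent substituent at this place, ortho to a large group and para to a carboxy group: in this assay, removing it gives a number 11.2 percentage points lower from compound 3 to compound 4 (beyond the scatter), a larger shift than the earlier exchange of the whole aryl group between compound 2 and compound 3 suggested. Fluoro adds nothing readable to the 3-carboxyphenyl group, since hydrogen in its place gives a number 0.4 percentage points lower from compound 1 to compound 4 (within the scatter), while the exchange for the (4-carboxyphenoxy)methyl group gives a number 14.8 percentage points lower from compound 2 to compound 4 (beyond the scatter), so the four compounds fall into two pairs, compound 1 with compound 4 and compound 2 with compound 3. Nothing available on these compounds accounts for the methoxy step.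

The compounds shown leave open whether the higher maximal response belongs to methoxy itself or would also appear with ethoxy, chloro or a hydroxy on the same aromatic carbon. They also leave open whether the methoxy step would hold with a tetrazole in place of the carboxy group, or with a shorter or longer chain in place of the butyl linker of the shared core.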